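Dropping the methoxy: from compound 2 to compound 3

This account rests on a few compounds, and the source may have more. Where it says the series, first, only, none or still open, it means among the compounds named here.

compound 1 `COc1ccccc1N1CCN(CCn2c(=O)[nH]c3ccccc32)CC1`: 1840 nM
compound 2 `COc1ccccc1N1CCN(CCCCn2c(=O)[nH]c3ccccc32)CC1`: 26 nM

Of the compounds shown here, two have been measured in an assay on HEK293 cells for displacement of a labelled ligand from 5-hydroxytryptamine receptor 7 (Homo sapiens); a higher number here means a weaker inhibitor, a lower number a stronger inhibitor. Compound 1 gives 1840 nM in this assay, while compound 2 gives 26 nM. Compound 2 therefore stands at the lower of the two numbers, and compound 1 sits far above it, well beyond the scatter of the assay.

Compound 3 `O=c1[nH]c2ccccc2n1CCCCN1CCN(c2ccccc2)CC1` is the next compound to be measured. It differs from compound 2 by a single change: hydrogen in place of methoxy on an aromatic carbon. Among the measured compounds shown here, no measured pair in this set shows this change, so the measured data give no direct guide to its size or direction.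

The step from compound 2 to compound 3 is expected to be a modest loss in this assay, a 3.5-fold higher number from compound 2 to compound 3 (0.54 log units; beyond the scatter). Compound 3 is accordingly estimated at 90 nM, with a range from 25 nM to 350 nM.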

Compound 3, inhibition constant: 48 nM
Compound 3: the middle estimate sits 1.9-fold (0.27 log units) above what was measured, and the stated range covers the measured number.
By their numbers in this assay, from the lowest: compounds 2 and 3 (each within the scatter of the next); then compound 1.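

In this assay, replacing 2-methoxyphenyl with phenyl gives a 1.8-fold higher number from compound 2 to compound 3 (0.27 log units; within the scatter), so this measurement cannot tell the two compounds apart. Among the compounds shown here, this is the first reading at this position: on the chain of compound 2, the methoxy group, on an aromatic carbon and ortho to a large group, gives way to hydrogen with no difference that the assay can resolve, although the change removes two heavy atoms and a hydrogen-bond acceptor. Nothing available here bears on why the change reads this way.

This single pair does not show how a chlorine atom, a hydroxyl group or an ethoxy group on that same carbon would read. It also leaves open whether replacing methoxy with hydrogen would read the same on the chain of compound 1.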